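From 4-hydroxyphenyl to 2,4-dichlorophenyl in a cytotoxicity series

The source may report more compounds than this note shows. Statements on the series, on what has been measured and on what is new or still open speak of the compounds shown alone.

Measured in a functional assay on HT-1080 cells (Homo sapiens) for cytotoxicity, read by MTT assay, with a stated time of 72 h; a higher number here means a weaker inhibitor, a lower number a stronger inhibitor:
- Compound 1 `COc1ccc(/C=C2\CCC/C(=C\c3cccc(Br)c3)C2=O)cc1OC`: 5200 nM
- Compound 2 `COc1ccc(/C=C2\CCC/C(=C\c3ccc(O)cc3)C2=O)cc1OC`: 16800 nM

Of these two compounds, compound 2 has the higher number at 16800 nM, making it the weaker inhibitor, and the gap to compound 1 lies beyond the scatter. The next compound, compound 3 `COc1ccc(/C=C2\CCC/C(=C\c3ccc(Cl)cc3Cl)C2=O)cc1OC`, keeps the shared core and changes one group: 2,4-dichlorophenyl in place of 4-hydroxyphenyl on a double-bonded chain carbon bound to a double-bonded ring carbon. Among the measured compounds shown here, only one measured step bears on this change: a 3.2-fold higher number from compound 1 to compound 2 (0.51 log units; beyond the scatter). That step introduced the 4-hydroxyphenyl group in place of 3-bromophenyl. For the measured compounds named here, no measured compound carries 2,4-dichlorophenyl, so the reference is only an approximate one. Because of a 3.2-fold higher number from compound 1 to compound 2 (0.51 log units; beyond the scatter), a modest step towards a lower number in this assay is expected on leaving 4-hydroxyphenyl for a halogen-bearing phenyl group. The expected step is a 3.4-fold lower number from compound 2 to compound 3 (0.53 log units; beyond the scatter). For compound 3 the estimated value is 5000 nM, with an expected range of 1800 nM to 14000 nM.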

Compound 3, half-maximal inhibitory concentration: 10500 nM
The estimate for compound 3 lay 2.1-fold (0.32 log units) below the measured number, within the range that was stated.
By their numbers in this assay, from the lowest: compound 1; then compounds 3 and 2 (each within the scatter of the next).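

In this assay, 2,4-dichlorophenyl and 4-hydroxyphenyl cannot be told apart at this place on a double-bonded chain carbon bound to a double-bonded ring carbon, with a 1.6-fold lower number from compound 2 to compound 3 (0.20 log units; within the scatter), even though the hydrogen-bond donor and acceptor of the hydroxyphenyl group are gone. A halogen-bearing phenyl group does not in itself match compound 1, since the data show a 2.0-fold higher number from compound 1 to compound 3 (0.31 log units; beyond the scatter), and compound 1 remains the strongest inhibitor of the three. Nothing available explains the difference between these phenyl groups.

The compounds shown leave open whether the gain of compound 1 belongs to bromine, or to the place it occupies on the phenyl ring. They also leave open how a phenyl group carrying an amine or a carboxylic acid would read here.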